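This account rests on a few compounds, and the source may have more. Where it says the series, first, only, none or still open, it means among the compounds named here.

In an ADME assay on 2209-23 cells (Homo sapiens) for cytotoxicity, read by WST assay and thymidine incorporation (on this read-out higher numbers stand for lower toxicity in this test and lower numbers for higher toxicity in this test), compound 1 (`CC(C)(C)[C@H]1C(O)=C(C2=CS(=O)(=O)c3cc(NS(C)(=O)=O)ccc3N2)C(=O)N1Cc1ccc(F)cc1`) gives > 50000 nM as a limit of the assay and not a number. Compound 2 (`CC(C)(C)[C@H]1C(O)=C(C2=CS(=O)(=O)c3cc(NS(C)(=O)=O)ccc3N2)C(=O)N1Cc1ccc(F)cc1F`) gives > 50000 nM as a limit too. Compound 1 therefore has a limit but no numerical position in the series, and the whole record so far reads: the limit of > 50000 nM in this assay, at which 2 of the 2 values shown sit.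

The change to follow leads to compound 3 (`CC(C)(C)[C@H]1C(O)=C(C2=CS(=O)(=O)c3cc([N+](=O)[O-])ccc3N2)C(=O)N1Cc1ccc(F)cc1`), with nitro in place of methanesulfonamido on an aromatic carbon of the core: nitro in place of methanesulfonamido on an aromatic carbon. Among the measured compounds shown here, the only measured step, a step that the two limits leave unreadable from compound 1 to compound 2, is fluoro in place of hydrogen on an aromatic carbon elsewhere in the molecule. For the measured compounds named here, it has no readable size, and no measured step covers the exchange made in compound 3.

With only the limit of > 50000 nM in this assay, at which 2 of the 2 values shown sit, as a guide, no step beyond the scatter is expected in this assay, and no direction can be set with confidence. The expected step is a number no higher from compound 1 to compound 3 (the limit leaves the size open) as an estimate. For compound 3 the estimated value is 50000 nM, with an expected range from 15000 nM to 100000 nM as its ends.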

Compound 3, half-maximal cytotoxic concentration: > 50000 nM
Compound 3 gave a limit, no number (the forecaster's own chance of this, stated with the estimate: 65%); the middle value lies on the limit itself.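

Compound 1 and compound 3 both rest on limits and not on numbers, so no step between them can be read: the limit of > 50000 nM in this assay, at which 3 of the 3 values shown sit.

The compounds shown leave open whether nitro or methanesulfonamido on the shared core, or fluoro on the benzyl ring, changes the half-maximal cytotoxic concentration in this assay, and where any numerical value would lie.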